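Propyl replacing trifluoromethyl on the quinoline-like core, expected toxicity

This account rests on a few compounds, and the source may have more. Where it says the series, first, only, none or still open, it means among the compounds named here.

Compound 1, `COc1ccc2nc(C)cc(OCC(=O)Nc3cc(C)cc(C)c3)c2c1`: in a toxicity assay on HepG2 cells (Homo sapiens) for inhibition, read by CellTiter-Glo, with a stated time of 48 h (on this read-out lower numbers stand for stronger inhibition and higher numbers for weaker inhibition), compound 1 gives 20000 nM.
Compound 2, `COc1ccc2nc(C(F)(F)F)cc(OCC(=O)Nc3cc(C)cc(C)c3)c2c1`: compound 2 reaches only the limit of this assay, > 100000 nM.
Compound 3, `CCOc1ccc2nc(C(F)(F)F)cc(OCC(=O)Nc3cc(C)cc(C)c3)c2c1`: compound 3 likewise reaches only the limit, > 100000 nM.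

Compound 2 therefore stands at the upper edge of what this assay reports; it shares that limit with compound 3, so the two cannot be ordered, and the step that the two limits leave unreadable from compound 2 to compound 3 is one the two limits leave unreadable. For the measured compounds named here, the one readable step is an at least 5.0-fold higher number from compound 1 to compound 2 (0.69 log units; beyond the scatter), where trifluoromethyl replaces methyl on the aromatic carbon of the shared core.

Compound 4, `CCCc1cc(OCC(=O)Nc2cc(C)cc(C)c2)c2cc(OC)ccc2n1`, has not been measured. It differs from compound 2 in one place: propyl in place of trifluoromethyl on an aromatic carbon. The change undoes the move from methyl to trifluoromethyl, replacing the fluorinated group with a plain three-carbon chain, so the step from compound 1 to compound 2 bears most directly on it; the limit of > 100000 nM in this assay, at which 2 of the 3 values shown sit, marks where compound 2 and compound 3 sit. An alkyl group on this carbon went with the lower number in compound 1, so a modest fall from compound 2 is expected, the step of an at least 2.0-fold lower number from compound 2 to compound 4 (0.30 log units; that floor lies within the scatter) being the estimate. For compound 4 the expected value in this assay is 50000 nM, between 15000 nM and 150000 nM.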

Compound 4, half-maximal inhibitory concentration in the HepG2 assay: 12600 nM
Beside the measured number, compound 4's estimate is 4.0-fold (0.60 log units) above it; measured number outside the range, below it.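

In the HepG2 assay propyl on the aromatic carbon next to the ring nitrogen gives an at least 7.9-fold lower number from compound 2 to compound 4 (0.89 log units; beyond the scatter), so among these compounds a readable number at this carbon is not confined to methyl. The longer chain also cannot be told apart from methyl: in the HepG2 assay there is a 1.6-fold lower number from compound 1 to compound 4 (0.20 log units; within the scatter), so going from methyl to propyl here registers no difference beyond the usual scatter. In the HepG2 assay compound 2 gives > 100000 nM, which is a limit of the assay and not a number, and the full size of its step to propyl stays unknown: the limit of > 100000 nM in the HepG2 assay, at which 2 of the 4 values shown sit.

Going by these compounds, whether an amine, a carboxylic acid or a chain longer than propyl at this carbon would keep the number in this range in the HepG2 assay stays open, and the step between the two trifluoromethyl compounds cannot be read. Solubility offers only one pair: in a physicochemical assay for solubility, in phosphate buffer, measured as kinetic solubility, with a stated time of 1 h, at pH 7.4 (on this read-out higher numbers stand for higher solubility and lower numbers for lower solubility), compound 2 gives 15000 nM and compound 4 gives 12000 nM. In the physicochemical assay this pair shows a 1.3-fold lower number from compound 2 to compound 4 (0.10 log units; within the scatter), and that single comparison cannot say how other groups at this carbon would read.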